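The source may hold more compounds than are shown below. What is called first, only, known or untested is meant among the compounds shown, and "the series" means these compounds.

Working notes on the series. Compound 1 `COc1ccc(S(=O)(=O)Nc2ccc(C)cc2Br)cc1N1CCNCC1` gives 7.94 nM in an assay on isolated protein for binding affinity to 5-hydroxytryptamine receptor 6 (Homo sapiens); a higher number here means a weaker inhibitor, a lower number a stronger inhibitor. Compound 2 `COc1ccc(S(=O)(=O)Nc2cc(Cl)c(Cl)cc2Cl)cc1N1CCNCC1` gives 5.01 nM in this assay, and compound 3 `COc1ccc(S(=O)(=O)Nc2cc(Br)cc(Br)c2Br)cc1N1CCNCC1` gives 2.51 nM in this assay. Compound 3 carries the lowest number of the three: a 3.2-fold lower number from compound 1 to compound 3 (0.50 log units; beyond the scatter), a modest step beyond the scatter, while a 2.0-fold lower number from compound 2 to compound 3 (0.30 log units; within the scatter), within the scatter, so compound 2 and compound 3 cannot be told apart. Compound 4 `COc1ccc(S(=O)(=O)Nc2cc(Br)cc(Br)c2Cl)cc1N1CCNCC1` is the next to be measured; it differs from compound 3 by chloro in place of bromo on an aromatic carbon. Among the compounds with values here, no measured step is this exact exchange. Within the data shown here, the comparison that bears on it is a 2.0-fold lower number from compound 2 to compound 3 (0.30 log units; within the scatter), the only measured pair in which chloro and bromo are exchanged, though with other changes alongside, and it stayed within the scatter, as did a 1.6-fold lower number from compound 1 to compound 2 (0.20 log units; within the scatter). A single halogen exchange is therefore expected to leave this assay nearly unchanged, with any shift more likely toward a higher number. For compound 4 the estimate is 3.5 nM, within 1.5 nM and 8 nM, which means an expected 1.4-fold higher number from compound 3 to compound 4 (0.14 log units; within the scatter).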

Compound 4, inhibition constant: 2.51 nM
For compound 4 the middle estimate is 1.4-fold (0.14 log units) above the measured one; measured number inside the range.
By their numbers in this assay, from the lowest: compounds 3, 4, 2 and 1 (each within the scatter of the next, the first and the last beyond it).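

Chloro in place of bromo at this position, ortho to a bromo group and para to a bromo group, is the first exact single-halogen exchange in the series, and it gives no change at the digits printed from compound 3 to compound 4 (within the scatter) in this assay, so here the two halogens cannot be told apart. The 3,5-dibromo-2-chlorophenyl group stands as the 2,3,5-tribromophenyl group does against the other two compounds, with a 2.0-fold lower number from compound 2 to compound 4 (0.30 log units; within the scatter) and a 3.2-fold lower number from compound 1 to compound 4 (0.50 log units; beyond the scatter), the latter alone a modest step beyond the scatter. No measurement to hand accounts for this flat response.

Open, as far as these compounds go, is whether an amine, a methoxy group or a carboxylic acid at this position would also leave this assay in place. Also open, from the compounds shown here alone, is whether chloro in place of either remaining bromo of compound 4 would behave the same way.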